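Swapping bromo for chloro on the para position of compound 3

A few compounds are considered here, and "the series" means these few. Any claim that something is new, unique, unknown or untested is made for them only; others in the source may bear on it.

Measured so far:
compound 1 `Cc1cc(O)ccc1C1=NN(c2ccc(S(C)(=O)=O)cc2)C(=O)CC1`: 33.3%
compound 2 `CS(=O)(=O)c1ccc(N2N=C(c3ccc(-c4ccccc4)cc3)CCC2=O)cc1`: 6.6%
compound 3 `CS(=O)(=O)c1ccc(N2N=C(c3ccc(Br)cc3)CCC2=O)cc1`: 10%

In a functional assay on the whole organism (strain Wistar) for inhibition, with Rattus norvegicus as the target, read by paw edema, with stated times of 30 min and 3 h, at a dose of 0.05 mmol/kg by the oral route (a higher number here means more inhibition at the dose given (going by the name of the read-out), a lower number less inhibition), compound 3 sits second of the three numbers, with compound 2 close by within the scatter and compound 1 beyond it. Compound 4 `CS(=O)(=O)c1ccc(N2N=C(c3ccc(Cl)cc3)CCC2=O)cc1` differs from compound 3 by chloro in place of bromo on an aromatic carbon. The nearest comparison is the swap of a group at the same place, which gave a number 3.4 percentage points higher from compound 2 to compound 3 (within the scatter), while the larger change of the whole ring gave a number 23.3 percentage points lower from compound 1 to compound 3 (beyond the scatter). A single-atom exchange between bromo and chloro is therefore expected to bring no step beyond the scatter, so a number 1 percentage points higher from compound 3 to compound 4 (within the scatter) is the estimate. Compound 4 is thus expected to give 11%, within 0% to 25%.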

Compound 4, a percentage reported as inhibition, in the whole organism at one dose (the size of the read-out at that dose, not a potency): 26.6%
The estimate for compound 4 lay 15.6 percentage points below the measured number; the measured number lies above the stated range.
By their numbers in this assay, from the lowest: compounds 2 and 3 (each within the scatter of the next); then compounds 4 and 1 (each within the scatter of the next).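

In this assay, this place on the aromatic ring responds to the exchange of a single atom: chloro in place of bromo gives a number 16.6 percentage points higher from compound 3 to compound 4 (beyond the scatter), and chloro in place of phenyl gives a number 20 percentage points higher from compound 2 to compound 4 (beyond the scatter). Changing the whole group to 4-chlorophenyl gives a number 6.7 percentage points lower from compound 1 to compound 4 (within the scatter), so the 4-hydroxy-2-methylphenyl group and the 4-chlorophenyl group cannot be told apart here. Nothing measured here explains the difference between chloro and bromo. From the compounds shown here alone, whether fluoro, methoxy or an amine at this place would read like chloro or like bromo stays open.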